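The source may report more compounds than this note shows. Statements on the series, on what has been measured and on what is new or still open speak of the compounds shown alone.

Compound 1 `COc1cc(OC)cc(-c2ccc(C(=O)N(Cc3cccc(OCCCCCC(=O)O)c3)C(C)C)cc2)c1` in an ADME assay on BJ cells (Homo sapiens) for cytotoxicity, read by CellTiter-Glo and resazurin assay, with a stated time of 72 h (on this read-out higher numbers stand for an effect only at larger amounts of compound and lower numbers for an effect already at smaller amounts), gives only a limit, > 26000 nM.
Compound 2 `CC(C)N(Cc1cccc(OCCCCCC(=O)O)c1)C(=O)c1ccc(-c2cc3ccccc3n2S(=O)(=O)c2ccccc2)cc1` in this assay gives only a limit, > 26000 nM.
Compound 3 `CCOC(=O)CCCCCOc1cccc(CN(C(=O)c2ccc(-c3cc(OC)cc(OC)c3)cc2)C(C)C)c1` in this assay gives only a limit, > 26000 nM.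

The difference between the cores of compound 1 and compound 2 is not broken down here. From compound 1 to compound 3 the change is ethyl in place of hydrogen on an oxygen next to a carbonyl group; the resulting step that the two limits leave unreadable from compound 1 to compound 3 stays unreadable, since both ends sit at the limit (the limit of > 26000 nM in this assay, at which 3 of the 3 values shown sit). Compound 4 `CCOC(=O)CCCCCOc1cccc(CN(C(=O)c2ccc(-c3cc4ccccc4n3S(=O)(=O)c3ccccc3)cc2)C(C)C)c1` is not yet measured; it carries the same change on the core of compound 2, (ethyl in place of hydrogen on an oxygen next to a carbonyl group), with the place described in the same words as for compound 1 and compound 3.

No value in this set lies inside the measurable range, so nothing readable can be transferred from the pair compound 1 and compound 3. The expectation for compound 4 rests on compound 2 sitting at the limit > 26000 nM and on the unreadable step that the two limits leave unreadable from compound 1 to compound 3. The step from compound 2 to compound 4 is expected to be a step that the limit leaves unreadable from compound 2 to compound 4, most likely again reported as a limit. Compound 4 is estimated at 40000 nM, with a range from 20000 nM to 100000 nM.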

Compound 4, half-maximal effective concentration: > 26000 nM
Compound 4: a limit, no number (the forecaster's own chance of this, stated with the estimate: 85%); the middle value is on the limit's open side.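

In this assay compound 4 gives > 26000 nM, a limit and not a number. Compound 2 also gives only a limit, so no step can be read from compound 2 to compound 4. The compounds shown leave open whether ethyl in place of hydrogen changes the read-out on either core, because all values share one limit: the limit of > 26000 nM in this assay, at which 4 of the 4 values shown sit.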